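The source may report more compounds than this note shows. Statements on the series, on what has been measured and on what is new or still open speak of the compounds shown alone.

Measured in a functional assay (aorta) with Rattus norvegicus as the target; on this read-out lower numbers stand for an effect already at smaller amounts and higher numbers for an effect only at larger amounts of compound:
- Compound 1 `COc1ccc(-c2nc(/N=C(\N)N(C)C)sc2-c2ccc(OC)cc2)cc1`: 4.8 uM
- Compound 2 `COc1ccc(-c2nc(/N=C(\N)N3CCOCC3)sc2-c2ccc(OC)cc2)cc1`: 66 uM
- Compound 3 `COc1ccc(-c2nc(C(=O)N=C(N)N)sc2-c2ccc(OC)cc2)cc1`: > 100 uM

The entry for compound 3 is a limit of the assay and not a number, as the limit of > 100 uM in this assay, at which 1 of the 3 values shown sits, records. Compound 4 `CCOC(=O)/C(C#N)=C/c1nc(-c2ccc(OC)cc2)c(-c2ccc(OC)cc2)s1` has not yet been measured. It carries a 2-cyano-2-(ethoxycarbonyl)ethenyl group in place of the group of compound 3, on an aromatic carbon of a five-membered aromatic ring with 1 nitrogen and 1 sulfur (a group of 9 heavy atoms (6 carbon, 1 nitrogen, 2 oxygen; no ring) in place of a group of 6 heavy atoms (2 carbon, 3 nitrogen, 1 oxygen; no ring), on an aromatic carbon).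

For the measured compounds named here, two measured steps bear on this exchange, both ending at compound 3 and both made on that aromatic carbon. One is large, an at least 20-fold higher number from compound 1 to compound 3 (1.31 log units; beyond the scatter). The other, an at least 1.5-fold higher number from compound 2 to compound 3 (0.18 log units; that floor lies within the scatter), has a floor within the scatter. Neither step contains the entering group, so they give no firm direction. Low numbers are so far confined to compound 1, at 4.8 uM, so compound 4 is expected to remain in the high range of this assay. The expected step is an at least 1.2-fold lower number from compound 3 to compound 4 (0.09 log units; that floor lies within the scatter), with no clear size beyond the scatter.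

The estimate for compound 4 is 80 uM, with an expected range from 20 uM to 300 uM.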

Compound 4, concentration for half-maximal effect: > 100 uM
Compound 4: no number, only a limit; the forecaster's own chance of this, stated with the estimate: 45%; middle value at least 1.2-fold (0.09 log units) away from the limit.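

In this assay compound 4 gives > 100 uM, which is a limit of the assay and not a number. The 2-cyano-2-(ethoxycarbonyl)ethenyl group, with 0 hydrogen-bond donors, is a second group on this aromatic carbon that yields no number, which adds to the values held at the limit: the limit of > 100 uM in this assay, at which 2 of the 4 values shown sit. The exchange of the group of compound 1 for this one gives an at least 20-fold higher number from compound 1 to compound 4 (1.31 log units; beyond the scatter), whereas the exchange of the morpholine-bearing group gives only an at least 1.5-fold higher number from compound 2 to compound 4 (0.18 log units; that floor lies within the scatter), and the step that joins the two limits cannot be read.

As far as these compounds go, whether compound 3 and compound 4 differ at all remains open. Also open, from the compounds shown here alone, is whether a simple amine or a carboxylic acid on this aromatic carbon would bring the number close to that of compound 1, 4.8 uM.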